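The source may hold more compounds than are shown below. What is called first, only, known or untested is meant among the compounds shown, and "the series" means these compounds.

Measured so far in a functional assay on SK-BR-3 cells (Homo sapiens) for antiproliferative activity, read by MTT assay, with a stated time of 72 h; a lower number here means a stronger inhibitor, a higher number a weaker inhibitor (all three results are limits):

- compound 1 `C=C(C)CCOC(=O)C[C@@H]1C(C(=O)OC)=CO[C@@H](O[C@@H]2O[C@H](COC(C)=O)[C@@H](OC(C)=O)[C@H](OC(C)=O)[C@H]2OC(C)=O)/C1=C/C` gives > 15000 nM (a limit)
- compound 2 `C/C=C1/[C@H](O[C@@H]2O[C@H](CO)[C@@H](O)[C@H](O)[C@H]2O)OC=C(C(=O)OC)[C@H]1CC(=O)OCCc1ccc2c(c1)OCCO2` gives > 20000 nM (a limit)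
- compound 3 `C/C=C1/[C@H](O[C@@H]2O[C@H](CO)[C@@H](O)[C@H](O)[C@H]2O)OC=C(C(=O)OC)[C@H]1CC(=O)OCCC` gives > 15000 nM (a limit)

Compound 1 stands only at a limit, not at a number (the limit of > 15000 nM in this assay, at which 2 of the 3 values shown sit). Compound 4 (`C/C=C1/[C@H](O[C@@H]2O[C@H](COC(C)=O)[C@@H](OC(C)=O)[C@H](OC(C)=O)[C@H]2OC(C)=O)OC=C(C(=O)OC)[C@H]1CC(=O)OC`) differs from compound 1 in one place (hydrogen in place of 2-methylprop-2-en-1-yl on a saturated chain carbon bound to an oxygen next to a carbonyl group), which turns ((3-methylbut-3-en-1-yl)oxy)carbonyl into methoxycarbonyl. Among the measured compounds shown here, the one measured step that bears on this is also a change on that chain (a step that the two limits leave unreadable from compound 2 to compound 3), and its size cannot be read. For the measured compounds named here, with no step of known size to go on, no change beyond the scatter is expected in this assay and no clear direction. The expected change is therefore small (a step that the limit leaves unreadable from compound 1 to compound 4). For compound 4 the estimated value is 20000 nM (expected range 8000 nM to 50000 nM).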

Compound 4, half-maximal inhibitory concentration: > 15000 nM
Compound 4 was reported as a limit (the forecaster's own chance of this, stated with the estimate: 85%); the middle value is on the limit's open side.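

Compound 1 and compound 4 both stand only at limits, so the step between them cannot be read. The compounds shown leave open what true potency each has and whether changing ((3-methylbut-3-en-1-yl)oxy)carbonyl to methoxycarbonyl alters it.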